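Series notes: ring-opened alcohol on the pyrazole nitrogen

The source may report more compounds than this note shows. Statements on the series, on what has been measured and on what is new or still open speak of the compounds shown alone.

Measured so far:
compound 1, `Cc1c(Nc2nc(N)c3c(C#N)c(N4CCC[C@H]4C)n(C)c3n2)cnn1[C@H]1CCOC1`, 51 nM;
compound 2, `Cc1c(Nc2nc(N)c3c(C#N)c(N4CCC[C@H]4C)n(C)c3n2)cnn1CC1(O)COC1`, 120 nM;
compound 3, `C[C@@H]1CCCN1c1c(C#N)c2c(N)nc(Nc3cn(C)nc3Cl)nc2n1C`, 54 nM.

In an assay on HEK293 cells for inhibition of Leucine-rich repeat serine/threonine-protein kinase 2 variant G2019S (Homo sapiens), with a stated time of 48 h (a lower number here means a stronger inhibitor, a higher number a weaker inhibitor), compound 2 gives the highest of the three numbers; compound 3 gives 54 nM and compound 1 gives 51 nM, both beyond the scatter from compound 2. Compound 4 is `Cc1c(Nc2nc(N)c3c(C#N)c(N4CCC[C@H]4C)n(C)c3n2)cnn1CC(C)(C)O`; it differs from compound 2 by 1-hydroxy-1-methylethyl in place of 3-hydroxyoxetan-3-yl on a saturated chain carbon bound to an aromatic nitrogen. Among the compounds with values here, the only measured step at this position is a 2.4-fold higher number from compound 1 to compound 2 (0.37 log units; beyond the scatter), a modest shift, and there is no measured pair that exchanges the ring for an open chain here. The expected step of a 1.5-fold lower number from compound 2 to compound 4 (0.18 log units; within the scatter) is therefore a modest move toward lower numbers, though it may stay within scatter. Compound 4 is expected at 80 nM, range 35 nM to 180 nM.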

Compound 4, half-maximal inhibitory concentration: 120 nM
Estimate against measurement, compound 4: 1.5-fold (0.18 log units) below; the range from low to high includes it.
By their numbers in this assay, from the lowest: compounds 1 and 3 (each within the scatter of the next); then compounds 2 and 4 (each within the scatter of the next).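

In this assay, an open chain at this position reads like the ring: 1-hydroxy-1-methylethyl in place of 3-hydroxyoxetan-3-yl gives no change at the digits printed from compound 2 to compound 4 (within the scatter) on a saturated chain carbon bound to an aromatic nitrogen. Against oxolan-3-yl, 2-hydroxy-2-methylpropyl gives a 2.4-fold higher number from compound 1 to compound 4 (0.37 log units; beyond the scatter) and so matches the gap already seen with compound 2. Nothing available explains either step.

Still open, as far as these compounds go, is whether the hydroxyl itself accounts for that gap. A methyl ether or an amine in its place on the chain would test this.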